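Bromine for chlorine on the thiophene of a kinase inhibitor

A few compounds are considered here, and "the series" means these few. Any claim that something is new, unique, unknown or untested is made for them only; others in the source may bear on it.

Two measured compounds share one core and differ only in the chlorine-bearing thiophene attached to the carbonyl. Compound 1, `CC(C)Nc1sc(C(=O)c2ccc(Cl)s2)c(N)c1C#N`, gives 192 nM in an assay for inhibition of Maternal embryonic leucine zipper kinase (Homo sapiens), read by ADP-Glo, with a stated time of 0.5 h; on this read-out higher numbers stand for weaker inhibition and lower numbers for stronger inhibition. Compound 2, `CC(C)Nc1sc(C(=O)c2cc(Cl)cs2)c(N)c1C#N`, gives 575 nM in this assay. Among the measured compounds shown here, of the two numbers so far, compound 2 stands highest, and the only measured step is a 3.0-fold higher number from compound 1 to compound 2 (0.48 log units; beyond the scatter). Compound 3, `CC(C)Nc1sc(C(=O)c2cc(Br)cs2)c(N)c1C#N`, has not been measured; it differs from compound 2 by bromo in place of chloro on an aromatic carbon. For the measured compounds named here, no measured step exchanges one halogen for another: the single known step swaps 5-chlorothiophen-2-yl for 4-chlorothiophen-2-yl, so it bears on compound 3 only indirectly, by showing how much a change on this ring can move the number. Going by the values given here, with no direct precedent, the expected step in this assay is small and need not exceed the scatter, and the estimated step is a 1.2-fold lower number from compound 2 to compound 3 (0.06 log units; within the scatter). Compound 3 is therefore expected to give about 500 nM, within a range from 220 nM to 1150 nM.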

Compound 3, half-maximal inhibitory concentration: 599 nM
Estimate against measurement, compound 3: 1.2-fold (0.08 log units) below; the measured number falls inside the stated range.
By their numbers in this assay, from the lowest: compound 1; then compounds 2 and 3 (each within the scatter of the next).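

In this assay, among the compounds shown here, the step of a 1.0-fold higher number from compound 2 to compound 3 (0.02 log units; within the scatter) is the first exchange of one halogen for another, and it lies within the scatter, so on this aromatic carbon, two ring bonds from the ring sulfur, chloro and bromo cannot be told apart. Compound 1 remains separate from both, and the step of a 3.1-fold higher number from compound 1 to compound 3 (0.49 log units; beyond the scatter) is beyond the scatter and closely matches the earlier step of a 3.0-fold higher number from compound 1 to compound 2 (0.48 log units; beyond the scatter), so the gap to compound 1 reads the same whichever of these two halogens the 4-substituted thiophene carries. No supporting measurement accompanies these numbers, so the close match between chloro and bromo remains an observation without an explanation.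

The compounds shown cannot say whether bromo in place of chloro would read the same on the thiophene of compound 1, where the chlorine sits elsewhere on the ring. They also leave open how this same aromatic carbon would respond to a group unlike either halogen, such as a methyl group, a methoxy group or an amine.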